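Methyl on the benzoyl ring of the furan analogue

The source may hold more compounds than are shown below. What is called first, only, known or untested is meant among the compounds shown, and "the series" means these compounds.

Two members of the series have been measured in a functional assay on A549 cells (Homo sapiens) for cytotoxicity, read by MTT assay, with a stated time of 48 h; a higher number here means a weaker inhibitor, a lower number a stronger inhibitor. Compound 1 `COc1cc(-c2nnc3n2NC(c2cccs2)C(C(=O)c2ccc(C)cc2)S3)cc(OC)c1OC` gives 12700 nM in this assay. Going by the values given here, compound 2 `COc1cc(-c2nnc3n2NC(c2ccco2)C(C(=O)c2ccccc2)S3)cc(OC)c1OC` gives 33400 nM in this assay, the highest of the two numbers; its only neighbour is compound 1, whose number sits lower, beyond the scatter. Compound 1 and compound 2 differ in more than one place at once, so the two values say nothing about any single change on its own.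

Compound 3 `COc1cc(-c2nnc3n2NC(c2ccco2)C(C(=O)c2ccc(C)cc2)S3)cc(OC)c1OC` has not yet been measured. It differs from compound 2 as follows: methyl in place of hydrogen on an aromatic carbon. Among the compounds with values here, no measured pair shows this change alone, and compound 1 against compound 2 is not such a pair, since it carries a second difference as well. The step from compound 2 to compound 3 in this assay is therefore expected to be small and toward a lower number, possibly not beyond the scatter, giving a 1.5-fold lower number from compound 2 to compound 3 (0.18 log units; within the scatter). Compound 3 is estimated at 22000 nM, with a range from 9000 nM to 55000 nM.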

Compound 3, half-maximal inhibitory concentration: > 100000 nM
Compound 3: no number, only a limit (the forecaster's own chance of this, stated with the estimate: 5%); middle value at least 4.5-fold (0.65 log units) from the limit.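

The reading for compound 3 is a limit of the assay and not a number: the limit of > 100000 nM in this assay, at which 1 of the 3 values shown sits.

Methyl in place of hydrogen on an aromatic carbon, para to a large group, can now be read as a single change for the first time, and in this assay it gives an at least 2.9-fold higher number from compound 2 to compound 3 (0.47 log units; beyond the scatter), so on the furan side the phenyl to 4-methylphenyl change moves the read-out toward weaker inhibition rather than leaving it in place. With the 4-methylphenyl group held, furan-2-yl in place of thiophen-2-yl on a saturated ring carbon gives an at least 7.8-fold higher number from compound 1 to compound 3 (0.89 log units; beyond the scatter), which shows that the ring on the saturated carbon decides whether a 4-methylphenyl compound stays within the measurable range of the assay.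

As far as these compounds go, both steps are lower bounds, so their full sizes remain open, as does whether the methyl change would run the same way with thiophen-2-yl in place. Also open, from the compounds shown here alone, is how an amine, a carboxylic acid or a longer chain such as ethyl would read on that aromatic carbon.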